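The source may report more compounds than this note shows. Statements on the series, on what has been measured and on what is new or still open speak of the compounds shown alone.

Compound 3 `COc1ccc(NC(=O)/C=C/c2coc3cc(OC)ccc3c2=O)cc1` is a limit case: in a functional assay (QGY7701 cells, Homo sapiens) for inhibition, read by MTT assay, with a stated time of 48 h (a lower number here means a stronger inhibitor, a higher number a weaker inhibitor), compound 3 gives only the limit > 100000 nM. Compound 1 `COc1ccc2c(=O)c(/C=C/C(=O)Nc3cc(C)ccc3C)coc2c1` likewise reaches only the limit > 100000 nM. Compound 2 `COc1ccc2c(=O)c(/C=C/C(=O)Nc3ccccc3OC)coc2c1`, by contrast, gives a measured 17600 nM, so the step of an at least 5.6-fold higher number from compound 2 to compound 3 (0.75 log units; beyond the scatter) is readable, while the step that the two limits leave unreadable from compound 1 to compound 3 is not, both compounds sitting at the limit of > 100000 nM in this assay, at which 2 of the 3 values shown sit. Compound 4 `COc1ccc2c(=O)c(/C=C/C(=O)Nc3ccccc3C)coc2c1` differs from compound 3 by 2-methylphenyl in place of 4-methoxyphenyl on an amide-type nitrogen. The change from compound 1 to compound 2 an at least 5.6-fold lower number from compound 1 to compound 2 (0.75 log units; beyond the scatter) shows a 2-substituted phenyl can lower the number, yet compound 1 also carries a 2-methyl and stays at the limit. The writer therefore expects compound 4 to give 50000 nM within 10000 nM to 200000 nM, a step of an at least 2.0-fold lower number from compound 3 to compound 4 (0.30 log units; that floor lies within the scatter).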

Compound 4, half-maximal inhibitory concentration: 22500 nM
Compound 4: the middle estimate sits 2.2-fold (0.35 log units) above what was measured, and the stated range covers the measured number.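

With methyl in place of methoxy, this assay shows a 1.3-fold higher number from compound 2 to compound 4 (0.11 log units; within the scatter), so 2-methylphenyl and 2-methoxyphenyl on the amide-type nitrogen cannot be told apart. Hydrogen in place of methyl gives an at least 4.4-fold lower number from compound 1 to compound 4 (0.64 log units; beyond the scatter), so the extra methyl of the 2,5-dimethylphenyl goes with the loss in compound 1, while 2-methylphenyl in place of 4-methoxyphenyl gives an at least 4.4-fold lower number from compound 3 to compound 4 (0.64 log units; beyond the scatter). Compound 1 and compound 3 are limits, so both steps give only a floor: the limit of > 100000 nM in this assay, at which 2 of the 4 values shown sit.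

On these data alone, whether 2-chlorophenyl or 2-aminophenyl on the amide-type nitrogen would differ from compound 2 and compound 4 stays open. So does the effect of hydrogen in place of the methoxy on the shared core.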